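Tetrazole against carboxylic acid across two trifluoromethyl cores

A few compounds are considered here, and "the series" means these few. Any claim that something is new, unique, unknown or untested is made for them only; others in the source may bear on it.

Compound 2 `FC(F)(F)c1ccc2cc(-c3nn[nH]n3)cnc2c1` and compound 3 `FC(F)(F)c1cccc2cc(-c3nn[nH]n3)cnc12` hold the same atoms joined differently; the difference between the two cores is not broken down here. In a functional assay on the whole organism (strain Sprague-Dawley) for inhibition, with Rattus norvegicus as the target (on this read-out lower numbers stand for an effect already at smaller amounts and higher numbers for an effect only at larger amounts of compound), compound 2 gives 25 mg/kg. In this assay compound 3 gives 25 mg/kg, level with compound 2 within the scatter of the method.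

Compound 1 `O=C(O)c1cnc2cc(C(F)(F)F)ccc2c1` differs from compound 2 in one place: carboxy in place of 2H-tetrazol-5-yl on an aromatic carbon. For compound 1 in this assay only a limit of the assay is reported, > 25 mg/kg. The step of a number no lower from compound 2 to compound 1 (the limit leaves the size open); its size is open because of the limit of > 25 mg/kg in this assay, at which 1 of the 3 values shown sits.

Compound 4 `O=C(O)c1cnc2c(C(F)(F)F)cccc2c1` has not been measured in this assay. It carries the same change, now set on compound 3: carboxy in place of 2H-tetrazol-5-yl on an aromatic carbon. The place is the same word for word as in the step from compound 2 to compound 1, so the change is taken as the same. For compound 4 the expected step is a 2.0-fold higher number from compound 3 to compound 4 (0.30 log units; within the scatter), resting on the step of a number no lower from compound 2 to compound 1 (the limit leaves the size open) seen on the other core. Compound 4 is estimated at 50 mg/kg in this assay, with a likely range from 20 mg/kg to 150 mg/kg, and most probably once more only a limit will be reported.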

Compound 4, minimum effective dose: 75 mg/kg
Compound 4: middle estimate off by 1.5-fold (0.18 log units), on the low side; the range from low to high includes it.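

On the core of compound 3, this assay shows a 3.0-fold higher number from compound 3 to compound 4 (0.48 log units; beyond the scatter) for carboxy in place of 2H-tetrazol-5-yl on an aromatic carbon, a modest step. On the core of compound 2 the same change points in no opposite direction, but its size cannot be read, because compound 1 is reported only as a limit of the assay: the limit of > 25 mg/kg in this assay, at which 1 of the 4 values shown sits. The two cores therefore do not contradict each other on direction, but the data do not show that the size of the step carries from one core to the other: the same change on two cores in this assay, a number no lower (the limit leaves the size open) from compound 2 to compound 1 and a 3.0-fold higher number (0.48 log units; beyond the scatter) from compound 3 to compound 4; the limit leaves it open whether they differ.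

The compounds shown leave open whether an amide or an acyl sulfonamide at the same place would follow the tetrazole or the carboxy compounds on either core. They also leave open whether the change behaves alike on a core bearing chlorine or a methoxy group instead of trifluoromethyl, and a single readable step gives no rule for the series.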